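This account rests on a few compounds, and the source may have more. Where it says the series, first, only, none or still open, it means among the compounds named here.

Measured in a functional assay on CCRF-CEM cells (Homo sapiens) for inhibition, read by MTT assay, with a stated time of 72 h; a higher number here means a weaker inhibitor, a lower number a stronger inhibitor:
- compound 1 `COc1cc(NC(C)CCCNC(=O)NNC(=O)Nc2ccc(F)cc2)c2ncccc2c1`: 118000 nM
- compound 2 `COc1cc(NC(C)CCCNC(=O)NNC(=O)Nc2ccc(Br)cc2)c2ncccc2c1`: 110000 nM
- compound 3 `COc1cc(NC(C)CCCNC(=O)Nc2cc(C(F)(F)F)cc(C(F)(F)F)c2)c2ncccc2c1`: 4100 nM

In this assay, a lower number means a stronger inhibitor. Compound 1 lies within the usual scatter of compound 2, while compound 3 gives a clearly lower number than either.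

The next compound to be tested is compound 4 `COc1cc(NC(C)CCCNC(=O)NNC(=O)Nc2cccc(F)c2)c2ncccc2c1`. It has the same atoms as compound 1, joined differently: 3-fluorophenyl in place of 4-fluorophenyl on an amide-type nitrogen. In plain terms, 3-fluorophenyl stands in place of 4-fluorophenyl on an amide-type nitrogen.

For the measured compounds named here, only one measured step bears on this change, and only indirectly: a 1.1-fold lower number from compound 1 to compound 2 (0.03 log units; within the scatter). That step puts bromo in place of fluoro on an aromatic carbon, and it stays within the scatter. Going by the values given here, no measured pair shows directly what moving the fluoro does, so no step beyond the scatter is expected, in either direction. The estimate amounts to a 1.1-fold lower number from compound 1 to compound 4 (0.05 log units; within the scatter), an expected change that stays within the scatter.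

For compound 4, the expected value is 105000 nM, with an estimated range of 55000 nM to 190000 nM.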

Compound 4, half-maximal inhibitory concentration: 98000 nM
Compound 4: the middle estimate sits 1.1-fold (0.03 log units) above what was measured; measured number inside the range.
By their numbers in this assay, from the lowest: compound 3; then compounds 4, 2 and 1 (each within the scatter of the next).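

In this assay, moving the fluorine around the ring, with 3-fluorophenyl in place of 4-fluorophenyl on an amide-type nitrogen, gives a 1.2-fold lower number from compound 1 to compound 4 (0.08 log units; within the scatter). Putting 3-fluorophenyl in place of 4-bromophenyl at the same nitrogen gives a 1.1-fold lower number from compound 2 to compound 4 (0.05 log units; within the scatter), so these numbers do not tell compounds 1, 2 and 4 apart, whether the halogen or its place on the ring is changed. Nothing measured alongside these values offers an explanation for this result.

Going by these compounds, whether a nitrile, an amine or a carboxylic acid on this ring would give a number beyond the scatter remains open. Compound 3 differs from these compounds in more than one place, so the shown data cannot say which difference goes with its clearly lower number.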